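A few compounds are considered here, and "the series" means these few. Any claim that something is new, unique, unknown or untested is made for them only; others in the source may bear on it.

Among the compounds with values here, compound 1 `Cc1ccc(-c2cs/c(=N/NC(=O)CSc3nncn3C)n2-c2ccccc2)cc1` gives 72% in a functional assay on C6 cells (Rattus norvegicus) for cytotoxicity, read by MTT assay, with a stated time of 24 h, tested at 12 ug/mL (on this read-out lower numbers stand for a stronger effect and higher numbers for a weaker effect at the one concentration tested), the highest of the two numbers so far, although compound 2 `Cn1cnnc1SCC(=O)N/N=c1/scc(-c2ccc(C#N)cc2)n1-c1ccccc1`, at 62.6%, sits within the scatter of it: a number 9.4 percentage points lower from compound 1 to compound 2 (within the scatter). Compound 3 `Cc1ccc(-c2cs/c(=N/NC(=O)CSc3ncccn3)n2-c2ccccc2)cc1` differs from compound 1 in another part of the molecule: pyrimidin-2-yl in place of 4-methyl-4H-1,2,4-triazol-3-yl on a sulfur. Within the data shown here, no measured step touches this part, so the single step known, from compound 1 to compound 2, gives no guide here. Compound 3 is therefore expected to stay close to compound 1, with no change at the digits printed from compound 1 to compound 3 (within the scatter) within the scatter, at an estimated 72%, between 55% and 88%.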

Compound 3, a percentage reported as activity, at one concentration (the size of the read-out at that concentration, not a potency): 83%
Compound 3: the middle estimate sits 11 percentage points below what was measured; the range from low to high includes it.
By their numbers in this assay, from the lowest: compounds 2 and 1 (each within the scatter of the next); then compound 3.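

The group on the sulfur matters in this assay: with pyrimidin-2-yl in place of 4-methyl-4H-1,2,4-triazol-3-yl there is a number 11 percentage points higher from compound 1 to compound 3 (beyond the scatter) and so a weaker effect. Unlike the cyano for methyl step on the aromatic carbon, this step lies beyond the usual scatter. Nothing available explains the change. Open, from the compounds shown here alone, is how an amine or a carboxylic acid on the chain in place of these rings would compare. Also open, going by these compounds, is whether the same ring swap would give a similar step on compound 2.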